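Swapping 2-methoxyphenyl for 2,3-dichlorophenyl on compound 2

The source may hold more compounds than are shown below. What is called first, only, known or untested is meant among the compounds shown, and "the series" means these compounds.

In a functional assay on SW-620 cells (Homo sapiens) for cytotoxicity, read by MTT assay, with a stated time of 72 h (on this read-out higher numbers stand for weaker inhibition and lower numbers for stronger inhibition), compound 1 (`COc1cccc(/C=C2\CCC/C(=C\c3cccc(Br)c3)C2=O)c1OC`) gives 8800 nM as a measured number. Compound 2 (`COc1ccccc1/C=C1\CCC/C(=C\c2cccc(OC)c2OC)C1=O`) gives > 20000 nM in this assay and this is a limit of the assay, not a number. Compound 2 therefore stands at the limit of > 20000 nM in this assay, at which 1 of the 2 values shown sits, and has no exact position of its own.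

Compound 3 (`COc1cccc(/C=C2\CCC/C(=C\c3cccc(Cl)c3Cl)C2=O)c1OC`) is reached from compound 2 by one change, 2,3-dichlorophenyl in place of 2-methoxyphenyl on a double-bonded chain carbon bound to a double-bonded ring carbon with 2,3-dichlorophenyl in place of 2-methoxyphenyl on a double-bonded chain carbon bound to a double-bonded ring carbon. Among the compounds with values here, the only measured step that bears on this is an at least 2.2-fold higher number from compound 1 to compound 2 (0.35 log units; beyond the scatter) and it is the change of 2-methoxyphenyl in place of 3-bromophenyl at that same place. Compound 3 puts a halogen-carrying phenyl group back there, so a return towards compound 1 (8800 nM) is expected. A modest move to a lower number is therefore expected in this assay and the expected step is an at least 2.5-fold lower number from compound 2 to compound 3 (0.39 log units; beyond the scatter) for now. The estimate for compound 3 is 8000 nM with 3000 nM to 20000 nM as the expected range.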

Compound 3, half-maximal inhibitory concentration: 16300 nM
Compound 3: middle estimate off by 2.0-fold (0.31 log units), on the low side, within the range that was stated.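

In this assay, the place on a double-bonded chain carbon bound to a double-bonded ring carbon now carries a second halogen-bearing phenyl group. Replacing 3-bromophenyl with 2,3-dichlorophenyl gives a 1.9-fold higher number from compound 1 to compound 3 (0.27 log units; within the scatter), so the two groups cannot be told apart at this place in this read-out. The comparison with 2-methoxyphenyl is less firm, as replacing it with 2,3-dichlorophenyl gives an at least 1.2-fold lower number from compound 2 to compound 3 (0.08 log units; that floor lies within the scatter), and this floor alone does not separate the two groups. Compound 2 carries a limit of the assay and not a number, so the true size of that step stays unknown: the limit of > 20000 nM in this assay, at which 1 of the 3 values shown sits.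

The compounds shown leave open how a plain phenyl group would read at this place, and so whether the halogens themselves matter to the values seen. They also leave open how a phenyl group carrying an amine or a carboxylic acid would read there, and whether any group at this place can bring the number far down from those printed here.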